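The compounds below may be only part of what the source reports. "The series", "measured", "known", "first", "only" and "open" are said of these compounds alone.

In an ADME assay on microsomes from liver (Rattus norvegicus) for metabolic stability, read by LC-MS, with a stated time of 10 min, tested at 0.5 uM (on this read-out lower numbers stand for a less stable compound and higher numbers for a more stable compound), compound 1 `c1ccc2c(c1)CN[C@@H](CN(CCC1CCNCC1)[C@H]1CCCc3cccnc31)C2` gives 17%, while compound 2 `NC(=O)N1CCN(CCCN(C[C@H]2Cc3ccccc3CN2)[C@H]2CCCc3cccnc32)CC1` gives 4%, the lower of the two numbers. Compound 3 `c1ccc2c(c1)CN[C@@H](CN(CCCCN1CCNCC1)[C@H]1CCCc3cccnc31)C2` differs from compound 2 by (piperazin-1-yl)methyl in place of 4-carbamoylpiperazin-1-yl on a saturated chain carbon, three bonds along the chain from an amine nitrogen. Going by the values given here, only one measured step bears on this change, a modest one that introduced the carbamoyl-bearing group: a number 13 percentage points lower from compound 1 to compound 2 (beyond the scatter). Compound 3 lacks that carbamoyl group, so a small upward step is expected, a number 8 percentage points higher from compound 2 to compound 3 (within the scatter). The estimated value for compound 3 is 12%, with an expected range of 3% to 25%.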

Compound 3, percent of the compound remaining: 15%
For compound 3 the middle estimate is 3 percentage points below the measured one, within the range that was stated.
By their numbers in this assay, from the lowest: compound 2; then compounds 3 and 1 (each within the scatter of the next).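

In this assay, (piperazin-1-yl)methyl in place of 4-carbamoylpiperazin-1-yl at this chain position gives a number 11 percentage points higher from compound 2 to compound 3 (beyond the scatter), so the low number of compound 2 does not hold once the carbamoyl group is gone. The other step, 2-(piperazin-1-yl)ethyl in place of piperidin-4-yl, gives a number 2 percentage points lower from compound 1 to compound 3 (within the scatter), so this swap of the ring at the chain end leaves the read-out unresolved. No measurement offered here explains either step.

The step from compound 2 still changes both the carbamoyl group and the chain length, and these remain unseparated. On these data alone, whether a morpholine ring or a longer chain at this position would change the read-out remains open.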